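A few compounds are considered here, and "the series" means these few. Any claim that something is new, unique, unknown or untested is made for them only; others in the source may bear on it.

Measured so far:

Compound 1, `CN(C)C(=O)c1cc2cnc(Nc3ccc(NC(=O)C4(C(=O)Nc5ccc(F)cc5)CC4)cc3)nc2n1C1CCCC1`: 65.4% in a functional assay on OVCAR-5 cells (Homo sapiens) for inhibition, read by CCK-8 assay, with a stated time of 72 h, tested at 1 uM; a higher number here means more inhibition of growth at the concentration tested, a lower number less inhibition of growth.
Compound 2, `CN(C)C(=O)c1cc2cnc(Nc3ccc(NC(=O)C4(C(=O)Nc5ccc(Cl)cc5)CC4)cc3)nc2n1C1CCCC1`: 8.1% in this assay.

Going by the values given here, compound 2 stands at the lowest of the two numbers in this assay; its only neighbour is compound 1, and the gap between them is a number 57.3 percentage points lower from compound 1 to compound 2 (beyond the scatter), a step that lies beyond the scatter.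

Compound 3, `CN(C)C(=O)c1cc2cnc(Nc3ccc(NC(=O)C4(C(=O)Nc5ccc(Br)cc5)CC4)cc3)nc2n1C1CCCC1`, differs from compound 2 in one place: bromo in place of chloro on an aromatic carbon. Among the compounds with values here, the single measured step that bears on this change is a number 57.3 percentage points lower from compound 1 to compound 2 (beyond the scatter), which shows that exchanging one halogen for another on this aromatic carbon produced a large fall. That step gives no direction for a further exchange of halogen, so the expectation for compound 3 rests on compound 2 alone and carries a wide range. Compound 3 is expected to show a step of a number 6.9 percentage points higher from compound 2 to compound 3 (within the scatter) in this assay, with an estimated value of 15%, between 0% and 50%.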

Compound 3, percent growth inhibition at one concentration: 13.7%
Compound 3: the middle estimate sits 1.3 percentage points above what was measured, within the range that was stated.
By their numbers in this assay, from the lowest: compounds 2 and 3 (each within the scatter of the next); then compound 1.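

In this assay the exchange of chloro for bromo on this aromatic carbon gives a number 5.6 percentage points higher from compound 2 to compound 3 (within the scatter) and so does not separate the 4-chlorophenyl and 4-bromophenyl compounds. The large fall is therefore not confined to chloro: bromo in place of fluoro gives a number 51.7 percentage points lower from compound 1 to compound 3 (beyond the scatter) and leaves compound 1, with its fluoro group, apart from both. Nothing available here explains why fluoro differs from the other two halogens at this position. The compounds shown leave open whether the higher number belongs to fluoro alone or would also appear with a hydrogen, a methoxy group or a nitrile at this place on the ring. They also leave open how these three halogen compounds would compare at other concentrations or in other cell lines.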